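Amide series: 4-phenylphenyl to 3-ethynylphenyl on ring nitrogen

This account rests on a few compounds, and the source may have more. Where it says the series, first, only, none or still open, it means among the compounds named here.

Compound 2 `O=C(NCCCCc1ccccc1)c1cccc(C2SCC(=O)N2c2ccc(-c3ccccc3)cc2)c1` is the reference point. In a functional assay on HOS-TE85 cells (Homo sapiens) for inhibition, read by CCK-8 assay, with a stated time of 72 h (a lower number here means a stronger inhibitor, a higher number a weaker inhibitor), compound 2 reaches only a limit of > 1000 nM. Compound 1 `O=C(NCCCCn1cccn1)c1cccc(C2SCC(=O)N2c2cccnc2)c1` likewise stops at a limit of > 1000 nM in this assay. Compound 3 `COc1ccccc1N1C(=O)CSC1c1cc(F)cc(C(=O)O)c1` also gives only a limit of > 1000 nM in this assay. For the measured compounds named here, no step between measured compounds that differ in one place is available, and the limit of > 1000 nM in this assay, at which 3 of the 3 values shown sit, covers every value shown, so compound 2 stands at the limit alongside the others rather than at a numbered place. Compound 4 `C#Cc1cccc(N2C(=O)CSC2c2cccc(C(=O)NCCCCc3ccccc3)c2)c1` differs from compound 2 by 3-ethynylphenyl in place of 4-phenylphenyl on an amide-type nitrogen in a ring. With nothing measured to lean on, no move beyond the scatter is expected in this assay, and a further limit is the most probable outcome. Compound 4 is estimated at 3000 nM, with a range from 800 nM to 12000 nM, which means an expected step that the limit leaves unreadable from compound 2 to compound 4.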

Compound 4, half-maximal inhibitory concentration: 149 nM
Beside the measured number, compound 4's estimate is 20-fold (1.30 log units) above it; the measured number lies below the stated range.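

In this assay, 3-ethynylphenyl in place of 4-phenylphenyl on the amide-type nitrogen in the ring gives an at least 6.7-fold lower number from compound 2 to compound 4 (0.82 log units; beyond the scatter). For the compounds shown here, this is the first readable step, and it shows that a change at this one position can bring a compound clear of the limit. Compound 4 alone has a numbered value, while the others remain at the limit: the limit of > 1000 nM in this assay, at which 3 of the 4 values shown sit.

Whether the triple bond or the loss of the second aromatic ring accounts for the step remains open. A nitrile or an amine in place of the ethynyl group would help separate the two.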